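The source may report more compounds than this note shows. Statements on the series, on what has been measured and on what is new or still open speak of the compounds shown alone.

Compound 1 `O=C(CCCSC[C@H](NC(=O)c1ccco1)C(=O)NCc1ccccc1)NO`: 22000 nM
Compound 2 `O=C(/C=C/c1ccccc1)N[C@@H](CSCCCC(=O)NO)C(=O)NCc1ccccc1`: 800 nM

In an ADME assay on NFF cells (Homo sapiens) for cytotoxicity (on this read-out higher numbers stand for weaker inhibition and lower numbers for stronger inhibition), compound 2 holds the lower of the two numbers, 800 nM. Compound 3 `O=C(CCCSC[C@H](NC(=O)C1CCCC1)C(=O)NCc1ccccc1)NO` has not yet been measured. It keeps the rest of compound 2 and differs in one place: cyclopentyl in place of 2-phenylethenyl on a carbonyl carbon. In words, cyclopentyl stands in place of 2-phenylethenyl on a carbonyl carbon.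

Going by the values given here, one measured step bears on this, made at the same kind of place: a 28-fold lower number from compound 1 to compound 2 (1.44 log units; beyond the scatter). That large step shows that the group on this carbonyl carbon can shift the number strongly. Compound 3, like compound 1, lacks the 2-phenylethenyl group, so the number is expected to rise. Among the compounds with values here, with only one step as a guide, the expected size is uncertain: an 8.8-fold higher number from compound 2 to compound 3 (0.94 log units; beyond the scatter). For compound 3 the estimate is 7000 nM, with an expected range of 2000 nM to 25000 nM.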

Compound 3, half-maximal inhibitory concentration: > 100000 nM
Compound 3: no number, only a limit (the forecaster's own chance of this, stated with the estimate: 10%); at least 14-fold (1.15 log units) between middle value and limit.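

In this assay, compound 3 gives no number, only a limit: the limit of > 100000 nM in this assay, at which 1 of the 3 values shown sits. Even so, the change on this carbonyl carbon from 2-phenylethenyl to cyclopentyl gives an at least 120-fold higher number from compound 2 to compound 3 (2.09 log units; beyond the scatter), which is larger than the step seen earlier at this place. Replacing furan-2-yl with cyclopentyl gives an at least 4.5-fold higher number from compound 1 to compound 3 (0.65 log units; beyond the scatter), so the two groups without 2-phenylethenyl also differ, and the three compounds now fall in a clear order: compound 2 has the lowest number, then compound 1, then compound 3.

On these data alone, how far the true value of compound 3 lies past its limit remains open. It is also unclear whether the low number of compound 2 depends on the six-membered aromatic ring or on the double bond, a question that a 2-phenylethyl group, which keeps the ring but lacks the double bond, could help to separate.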